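Working notes: methoxy for methyl across two cores

The compounds below may be only part of what the source reports. "The series", "measured", "known", "first", "only" and "open" are said of these compounds alone.

Compound 1 `Cc1ccc(N2CCN/C2=N\N)cc1` and compound 2 `COc1ccc(N2CCN/C2=N\N)cc1` share one core; compound 3 `Cc1ccccc1N1CCn2c1n[nH]c(=O)c2=O` and compound 4 `COc1ccccc1N1CCn2c1n[nH]c(=O)c2=O` share another, and the difference between the two cores is not broken down here. In an ADME assay on Vero cells (Chlorocebus sabaeus) for cytotoxicity, with a stated time of 72 h, tested at 10 ug/mL (on this read-out lower numbers stand for a weaker effect and higher numbers for a stronger effect at the one concentration tested), compound 1 gives 0%, compound 2 gives 0% and compound 3 gives 0%. The step of no change at the digits printed from compound 1 to compound 2 (within the scatter) accompanies the change (methoxy in place of methyl on an aromatic carbon). From compound 3 to compound 4 the change is methoxy in place of methyl on an aromatic carbon, the same kind of change, though the place differs: para to a group of 7 heavy atoms in the first pair, ortho to a large group in the second. Compound 4 remains to be measured. The step of no change at the digits printed from compound 3 to compound 4 (within the scatter) is expected to be flat, because the same kind of change gave no change at the digits printed from compound 1 to compound 2 (within the scatter). Compound 4 is estimated at 0% in this assay, between 0% and 10%.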

Compound 4, a percentage reported as inhibition, at one concentration (the size of the read-out at that concentration, not a potency): 26%
Compound 4: middle estimate off by 26 percentage points, on the low side, and the stated range ends below it.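

In this assay, methoxy in place of methyl on an aromatic carbon gives a number 26 percentage points higher from compound 3 to compound 4 (beyond the scatter). The result of this change therefore does not carry over unchanged between the two cores: the same change on two cores in this assay, no change at the digits printed (within the scatter) from compound 1 to compound 2 and a number 26 percentage points higher (beyond the scatter) from compound 3 to compound 4, 26 percentage points apart, beyond the scatter of two such steps

The two pairs differ in both core and the place of the change, and these data do not separate the two, nor does one pair per core establish a general rule. Still open, going by these compounds, is how the core of compound 3 responds to other groups on that carbon, such as a hydroxyl, an ethoxy or an amine. Also open, on these data alone, is whether methoxy gives the same result elsewhere on that ring.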